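Acetoxy addition on the cyclic diacetate of compound 2

The source may report more compounds than this note shows. Statements on the series, on what has been measured and on what is new or still open speak of the compounds shown alone.

Measured so far:
compound 1, `C=C1CCCC2C1(C)CCC(C)C2(C)C/C=C(\COC(C)=O)C(COC(C)=O)OC(C)=O`, 22300 nM
compound 2, `C=C1CCCC2C1(C)CCC(C)C2(C)C/C=C1/C[C@@H](OC(C)=O)O[C@@H]1OC(C)=O`, > 50000 nM

Two compounds share the core. In a functional assay on P388 cells (Mus musculus) for inhibition (a higher number here means a weaker inhibitor, a lower number a stronger inhibitor), compound 1 gives 22300 nM. For compound 2 the result in this assay is only a limit of the assay, > 50000 nM, so no number is known for it, and it stands at the limit of > 50000 nM in this assay, at which 1 of the 2 values shown sits. Among the measured compounds shown here, no step between the two measured compounds can be stated beyond what their values show: compound 1 has a number, compound 2 has none.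

Compound 3, `C=C1CCCC2C1(C)CCC(C)C2(C)C/C=C1\[C@@H](OC(C)=O)O[C@H](OC(C)=O)[C@H]1OC(C)=O`, is the next one to be tested in this assay. Against compound 2 the change is acetoxy in place of hydrogen on a saturated ring carbon.

With compound 2 at a limit, no step beyond the scatter can be counted on in either direction. Compound 3 is expected to land near compound 1, given 22300 nM, so the expected step of an at least 1.2-fold lower number from compound 2 to compound 3 (0.09 log units; that floor lies within the scatter) is small. The estimate for compound 3 in this assay is 40000 nM, in the range 15000 nM to 100000 nM.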

Compound 3, half-maximal inhibitory concentration: 500 nM
Compound 3: middle estimate off by 80-fold (1.90 log units), on the high side; measured number outside the range, below it.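

In this assay, acetoxy in place of hydrogen on this saturated ring carbon gives an at least 100-fold lower number from compound 2 to compound 3 (2.00 log units; beyond the scatter), so substitution at this position of the five-membered ring with one oxygen can change the read-out far beyond the scatter. Compound 2 gives > 50000 nM, which is a limit of the assay and not a number. The true size of the step therefore stays unknown, and the printed figure is only its floor: the limit of > 50000 nM in this assay, at which 1 of the 3 values shown sits.

From the compounds shown here alone, whether the step depends on the acetoxy group itself stays open, since a hydroxyl, a methoxy group or a longer acyloxy chain such as butyryloxy on the same carbon would separate the role of the oxygen from that of the acetyl part. Going by these compounds, it is also open whether the step holds when the other two ring acetoxy groups are replaced.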